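The compounds below may be only part of what the source reports. "The series", "measured", "known", "first", "only" and "open" are said of these compounds alone.

Working notes on the chromenone thiocarbamate series, measured in a functional assay on MCF7 cells (Homo sapiens) for antiproliferative activity, read by MTT assay, with a stated time of 72 h; a lower number here means a stronger inhibitor, a higher number a weaker inhibitor.

Compound 1 `CCOC(=O)c1cc(=O)c2cc(CSC(=S)N(C)c3ccccc3)ccc2o1` carries a methyl(phenyl)amino group on the thiocarbonyl carbon. In this assay compound 1 reaches only the limit of the assay, > 25000 nM, so no number is in hand for it; the limit is noted as the limit of > 25000 nM in this assay, at which 1 of the 2 values shown sits. Compound 2 `O=c1cc(CSC(=S)N2CCCC2)oc2ccccc12` shares the thiocarbamate motif but lacks the ester and carries pyrrolidin-1-yl; in this assay compound 2 gives 35800 nM. Both values point to weak inhibition in this part of the series.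

Compound 3 `CCOC(=O)c1cc(=O)c2cc(CSC(=S)N3CCCC3)ccc2o1` is compound 1 with pyrrolidin-1-yl in place of methyl(phenyl)amino on a thiocarbonyl carbon. The change thus moves compound 1 toward the pyrrolidin-1-yl substitution seen in compound 2, which itself sits at 35800 nM. With compound 1 known only as a limit, the step to compound 3 cannot be given a measured size; the expectation is for no step beyond the usual scatter, and an estimated change of a step that the limit leaves unreadable from compound 1 to compound 3 in this assay. On that basis compound 3 is expected to give about 35000 nM in this assay, within a range from 15000 nM to 90000 nM.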

Compound 3, half-maximal inhibitory concentration: > 25000 nM
Compound 3: only a limit was reported; the forecaster's own chance of this, stated with the estimate: 40%; the middle value is on the limit's open side.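

Compound 1 and compound 3 each stand only as a limit in this assay, so no step between them can be read: the limit of > 25000 nM in this assay, at which 2 of the 3 values shown sit.

The compounds shown leave open whether pyrrolidin-1-yl in place of methyl(phenyl)amino on a thiocarbonyl carbon changes antiproliferative activity at all, as neither compound has a measured number here.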